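A few compounds are considered here, and "the series" means these few. Any claim that something is new, unique, unknown or untested is made for them only; others in the source may bear on it.

Compound 1 `CCCCN(CC)Cc1c(C(F)(F)F)nc2n(-c3c(C)cc(C)cc3C)c(Cl)cn12` — 78 nM
Compound 2 `CCCCN(C)Cc1c(C(F)(F)F)nc2n(-c3c(C)cc(C)cc3C)c(Cl)cn12` — 310 nM
Compound 3 `Cc1cc(C)c(-n2c(Cl)cn3c(CN(CCC(F)(F)F)Cc4ccccc4)c(C(F)(F)F)nc23)c(C)c1` — 43 nM

The three measured compounds share one core and differ only in the two groups on the amine nitrogen. In an assay on cells for displacement of a labelled ligand from corticotropin-releasing factor receptor 1 (Homo sapiens), with a stated time of 100 min (on this read-out higher numbers stand for weaker inhibition and lower numbers for stronger inhibition), compound 3 gives the lowest number of the three; its nearest neighbour is compound 1, which stands higher by a margin within the scatter, so the two cannot be ordered, while compound 2 stands further off, beyond the scatter. For the measured compounds named here, the single one-place step on record, a 4.0-fold higher number from compound 1 to compound 2 (0.60 log units; beyond the scatter), concerns hydrogen in place of methyl on a saturated chain carbon bound to the amine nitrogen.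

Compound 4 `CCCCN(Cc1ccccc1)Cc1c(C(F)(F)F)nc2n(-c3c(C)cc(C)cc3C)c(Cl)cn12` is not yet measured. It differs from compound 3 by ethyl in place of trifluoromethyl on a saturated chain carbon, two bonds along the chain from an amine nitrogen. Going by the values given here, no measured step touches this position: the one recorded step changes the other group on the amine nitrogen, and the change from compound 1 to compound 3 alters two places at once. With nothing in the data bearing directly on the trifluoromethyl-to-ethyl exchange, a step in this assay of no more than the scatter in either direction is expected, a 1.0-fold higher number from compound 3 to compound 4 (0.02 log units; within the scatter). Compound 4 is therefore estimated at 45 nM, within a range of 15 nM to 130 nM.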

Compound 4, inhibition constant: 130 nM
Estimate against measurement, compound 4: 2.9-fold (0.46 log units) below, and the stated range covers the measured number.
By their numbers in this assay, from the lowest: compounds 3, 1 and 4 (each within the scatter of the next, the first and the last beyond it); then compound 2.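

In this assay, trifluoromethyl and ethyl are not interchangeable on this saturated chain carbon, two bonds along the chain from an amine nitrogen: the exchange gives a 3.0-fold higher number from compound 3 to compound 4 (0.48 log units; beyond the scatter), a modest step beyond the scatter, and so gives this position its first direct reading. The comparisons at the other chain on the amine nitrogen also separate: phenyl in place of hydrogen on a saturated chain carbon bound to the amine nitrogen gives a 2.4-fold lower number from compound 2 to compound 4 (0.38 log units; beyond the scatter), beyond the scatter, whereas phenyl in place of methyl there gives a 1.7-fold higher number from compound 1 to compound 4 (0.22 log units; within the scatter), within the scatter, so that pair cannot be ordered. No measurement at hand speaks to what lies behind these steps.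

Going by these compounds, the trifluoromethyl-to-ethyl exchange is read only once, with a single partner on the amine nitrogen, so it remains open whether the step would hold with the shorter chains of the other compounds in its place. Also open, on these data alone, is how a hydroxyl group, a nitrile, an amine or a longer chain would read on the same chain carbon.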